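A few compounds are considered here, and "the series" means these few. Any claim that something is new, unique, unknown or untested is made for them only; others in the source may bear on it.

Measured compounds in the series:
compound 1, `CC(C)NC(=O)NC1CC(C)(C)Oc2ccc(Cl)cc21`, 62000 nM
compound 2, `CC1(C)CC(NC(=O)Nc2ccccc2Cl)c2cc(Br)ccc2O1`, 19000 nM
compound 3, `COc1ccccc1NC(=S)NC1CC(C)(C)Oc2ccc(Br)cc21`, 22000 nM

All three were run in a functional assay on U-373MG ATCC cells (Homo sapiens) for inhibition, read by MTT assay, with a stated time of 72 h; on this read-out higher numbers stand for weaker inhibition and lower numbers for stronger inhibition. Compound 1 gives the highest number of the three; the nearest to it is compound 3, whose number is lower by more than the usual scatter, and compound 2 lies further off still, also beyond the scatter. Compound 1 therefore stands as the weakest inhibitor among these three measured compounds.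

The unmeasured compound 4, `CC1(C)CC(NC(=O)Nc2cccc(Cl)c2)c2cc(Cl)ccc2O1`, is reached from compound 1 by one change: 3-chlorophenyl in place of isopropyl on an amide-type nitrogen. Within the data shown here, no step between two measured compounds isolates this exact change, so the expectation rests on the shared core and on the fact that compound 2 and compound 3 both return lower numbers than compound 1. On that basis a moderate downward step in this assay from compound 1 to compound 4 is expected, of roughly the size seen between compound 1 and the other two, a 2.8-fold lower number from compound 1 to compound 4 (0.45 log units; beyond the scatter). For compound 4 the estimate is 22000 nM, with a range from 8000 nM to 60000 nM.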

Compound 4, half-maximal inhibitory concentration: 21000 nM
Beside the measured number, compound 4's estimate is 1.0-fold (0.02 log units) above it, within the range that was stated.
By their numbers in this assay, from the lowest: compounds 2, 4 and 3 (each within the scatter of the next); then compound 1.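

In this assay, the group on the amide-type nitrogen now has a step of its own: 3-chlorophenyl in place of isopropyl gives a 3.0-fold lower number from compound 1 to compound 4 (0.47 log units; beyond the scatter), a modest change towards stronger inhibition. Among these compounds, none of the earlier compounds formed a pair differing in one place, so this is the first reading of this position alone, and it shows that the read-out responds to the group held there. No measurement at hand accounts for the step.

The step does not separate the contribution of the ring from that of its chlorine; an unsubstituted phenyl on the same nitrogen would divide the two. Also open, as far as these compounds go, is how a saturated ring such as cyclohexyl, or a longer chain such as n-butyl, would read at this position.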